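This account rests on a few compounds, and the source may have more. Where it says the series, first, only, none or still open, it means among the compounds named here.

Compound 1, with the structure `ClCc1ccccc1Cn1cnc2c(Cl)nc(Cl)nc21`, was tested in a functional assay on M14 cells (Homo sapiens) for cytotoxicity, read by sulforhodamine B assay, with a stated time of 48 h (a lower number here means that less compound is tolerated, a higher number that more compound is tolerated), where compound 1 gives 5750 nM. Compound 2, with the structure `ClCc1ccccc1Cn1cnc2c(Cl)ncnc21`, differs from compound 1 by a single change, described as hydrogen in place of chloro on an aromatic carbon, and in this assay compound 2 gives 7240 nM. The step between them is a 1.3-fold higher number from compound 1 to compound 2 (0.10 log units; within the scatter). Compound 3, with the structure `ClCc1ccc(Cn2cnc3nc(Cl)nc(Cl)c32)cc1`, is built on a core that is related to that of compound 1 but arranged differently; the difference between the two cores is not broken down here. In this assay compound 3 gives 6910 nM, and its values against compound 1 and compound 2 lie within the scatter of one another, so no order among the three can be read from these numbers.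

Compound 4, with the structure `ClCc1ccc(Cn2cnc3ncnc(Cl)c32)cc1`, has not yet been measured. It differs from compound 3 by hydrogen in place of chloro on an aromatic carbon. The place of this change is described in the same words as for the change from compound 1 to compound 2, so it is the same change, made on the core of compound 3 rather than that of compound 1. The expected step is a 1.2-fold higher number from compound 3 to compound 4 (0.09 log units; within the scatter), because a 1.3-fold higher number from compound 1 to compound 2 (0.10 log units; within the scatter) was the outcome of this change once before and that step stayed within the scatter. For compound 4 the expected value in this assay is therefore 8500 nM, with a likely range from 4500 nM to 16000 nM.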

Compound 4, concentration lethal to 50% of the cells: 37200 nM
The estimate for compound 4 lay 4.4-fold (0.64 log units) below the measured number; measured number above the stated range.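

In this assay, hydrogen in place of chloro on the aromatic carbon between two ring nitrogen atoms gives a 5.4-fold higher number from compound 3 to compound 4 (0.73 log units; beyond the scatter) on the core of compound 3, a step that lies beyond the scatter, whereas the same change left the numbers on the core of compound 1 within the scatter. This change therefore did not carry over from one core to the other with the same size, and the two steps stand clearly apart: the same change on two cores in this assay, a 1.3-fold higher number (0.10 log units; within the scatter) from compound 1 to compound 2 and a 5.4-fold higher number (0.73 log units; beyond the scatter) from compound 3 to compound 4, 4.3-fold (0.63 log units) apart, beyond the scatter of two such steps. This shows only that, for these two pairs, the outcome of the change depended on the core that carried it; with a single pair on each core, it does not show which difference between the cores is responsible, nor whether the step would be of similar size on any further core in the series.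

The compounds shown leave open whether an amine, a methoxy group or a fluorine on that same carbon would give a number closer to that of compound 3 or to that of compound 4. They also leave open how the step would respond if an amine or a hydroxyl group took the place of the chlorine on the chloromethyl side chain.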